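Swapping the para substituent on the N-aryl ring

This account rests on a few compounds, and the source may have more. Where it says the series, first, only, none or still open, it means among the compounds named here.

Measured so far:
- compound 1 `O=C(Nc1ccc(Oc2ccnc3[nH]ccc23)cc1)c1cc2cccnc2n(-c2ccc(F)cc2)c1=O`: 210 nM
- compound 2 `O=C(Nc1ccc(Oc2ccnc3[nH]ccc23)cc1)c1cc2cccnc2n(-c2ccc(Br)cc2)c1=O`: 280 nM

Both were tested in a functional assay on A549 cells (Homo sapiens) for antiproliferative activity, read by MTT assay, with a stated time of 72 h; a lower number here means a stronger inhibitor, a higher number a weaker inhibitor. Compound 2 gives the higher of the two numbers, but the step of a 1.3-fold higher number from compound 1 to compound 2 (0.12 log units; within the scatter) is too small to separate it from compound 1. Compound 3 `COc1ccc(-n2c(=O)c(C(=O)Nc3ccc(Oc4ccnc5[nH]ccc45)cc3)cc3cccnc32)cc1` differs from compound 2 only by methoxy in place of bromo on an aromatic carbon. Among the compounds with values here, the one measured step at this position, fluoro to bromo, was within the scatter, so compound 3 is expected to stay near compound 2, with the step of a 1.1-fold higher number from compound 2 to compound 3 (0.03 log units; within the scatter) expected to remain small. For compound 3 the estimate is 300 nM, ranging from 120 nM to 750 nM.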

Compound 3, half-maximal inhibitory concentration: 930 nM
Compound 3: the middle estimate sits 3.1-fold (0.49 log units) below what was measured; the measured number lies above the stated range.
By their numbers in this assay, from the lowest: compounds 1 and 2 (each within the scatter of the next); then compound 3.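

Unlike the swap of fluoro for bromo, a change at this position can move the number beyond the scatter: putting in methoxy gives a 3.3-fold higher number from compound 2 to compound 3 (0.52 log units; beyond the scatter) and a 4.4-fold higher number from compound 1 to compound 3 (0.65 log units; beyond the scatter) in the same direction. The position therefore does not accept every group equally, and among the three shown, methoxy alone stands apart. No measurement here explains why this change weakens the compounds.

Going by these compounds, whether the loss belongs to methoxy alone stays open. An amine, a hydroxy group or a longer chain such as ethoxy at this place would test that.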